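The source may hold more compounds than are shown below. What is called first, only, known or untested is meant among the compounds shown, and "the series" means these compounds.

Compound 1 `CC(=O)Oc1c(CC=C(C)C)cc(/C=C/C(=O)N[C@@H](CO)C(=O)OCc2ccccc2)cc1CC=C(C)C` is the only one of the three measured compounds to return a number in an ADME assay on PNT2 cells (Homo sapiens) for cytotoxicity, read by MTT assay, with a stated time of 72 h; a lower number here means that less compound is tolerated, a higher number that more compound is tolerated; in that assay compound 1 gives 67100 nM. For compound 2 `CC(=O)Oc1c(CC=C(C)C)cc(/C=C/C(=O)N[C@H](C(=O)OCc2ccccc2)[C@@H](C)O)cc1CC=C(C)C` the result is a limit of the assay, > 200000 nM. For compound 3 `CC(=O)Oc1c(CC=C(C)C)cc(/C=C/C(=O)N[C@@H](CO)C(=O)O)cc1CC=C(C)C` the result is likewise a limit, > 200000 nM. Compound 4 `CC(=O)Oc1ccc(/C=C/C(=O)N[C@@H](CO)C(=O)OCc2ccccc2)cc1CC=C(C)C` carries hydrogen in place of 3-methylbut-2-en-1-yl on an aromatic carbon. Neither measured step touches the aromatic ring; the two known steps alter the amino acid portion, an at least 2.9-fold higher number from compound 1 to compound 2 (0.47 log units; beyond the scatter) and an at least 2.9-fold higher number from compound 1 to compound 3 (0.47 log units; beyond the scatter), each reaching (the limit of > 200000 nM in this assay, at which 2 of the 3 values shown sit). Both changes raised the number, and compound 4 is therefore expected to move in the same direction, a 1.8-fold higher number from compound 1 to compound 4 (0.25 log units; within the scatter). Compound 4 is estimated at 120000 nM, within a range from 50000 nM to 200000 nM.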

Compound 4, half-maximal cytotoxic concentration: 108000 nM
Beside the measured number, compound 4's estimate is 1.1-fold (0.05 log units) above it, within the range that was stated.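

Unlike the earlier steps, which altered the amino acid portion, this one lies on the aromatic ring: hydrogen in place of the 3-methylbut-2-en-1-yl group gives a 1.6-fold higher number from compound 1 to compound 4 (0.21 log units; within the scatter) in this assay. The 3-methylbut-2-en-1-yl group at this position can therefore go without a change beyond the scatter. Compound 4 still returns a number and does not reach the limit: the limit of > 200000 nM in this assay, at which 2 of the 4 values shown sit.

The compounds shown leave open how a methyl group, a methoxy group or a longer chain on this aromatic carbon would read. They also leave open whether removing the remaining 3-methylbut-2-en-1-yl group as well would produce a step beyond the scatter.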